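A few compounds are considered here, and "the series" means these few. Any claim that something is new, unique, unknown or untested is made for them only; others in the source may bear on it.

Measured so far in a functional assay on HeLa cells (Homo sapiens) for antiproliferative activity, read by MTT assay, with a stated time of 48 h; on this read-out higher numbers stand for weaker inhibition and lower numbers for stronger inhibition:
- compound 1 `CN1CCN(CCn2c(N)c(-c3nc4ccccc4[nH]3)c3nc(C#N)c(C#N)nc32)CC1`: > 50000 nM, a limit of the assay
- compound 2 `CCCn1c(N)c(-c2nc3ccccc3[nH]2)c2nc(C#N)c(C#N)nc21`: > 50000 nM, a limit of the assay

Compound 1 stands only at a limit in this assay; no number is attached to it. For the measured compounds named here, the one measured step, a step that the two limits leave unreadable from compound 1 to compound 2, is unreadable in size because both of its ends sit at the same limit, as the limit of > 50000 nM in this assay, at which 2 of the 2 values shown sit, shows. Going by the values given here, nothing so far separates any compound from another.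

Compound 3 `CN(C)CCCCCn1c(N)c(-c2nc3ccccc3[nH]2)c2nc(C#N)c(C#N)nc21` is not yet measured. It differs from compound 1 by 3-(dimethylamino)propyl in place of 4-methylpiperazin-1-yl on a saturated chain carbon, two bonds along the chain from an aromatic nitrogen.

Among the compounds with values here, the only step that bears on the change at this position, the one from compound 1 to compound 2, is unreadable, so it gives no direction and no size. Both measured compounds sit at the limit, and the estimate for compound 3 therefore rests on that alone. The step expected from compound 1 to compound 3 in this assay is a number no higher from compound 1 to compound 3 (the limit leaves the size open), with no direction beyond the scatter. Compound 3 is estimated in this assay at 50000 nM, in the range 15000 nM to 150000 nM, and most likely again reported only as a limit.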

Compound 3, half-maximal inhibitory concentration: 10800 nM
For compound 3 the middle estimate is 4.6-fold (0.67 log units) above the measured one; measured number below the stated range.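

In this assay, for the compounds shown here, the chain on the aromatic nitrogen is the first place where a change gives a readable result: 5-(dimethylamino)pentyl in place of 2-(4-methylpiperazin-1-yl)ethyl gives an at least 4.6-fold lower number from compound 1 to compound 3 (0.66 log units; beyond the scatter), and 2-(dimethylamino)ethyl in place of hydrogen, three bonds along the chain from the aromatic nitrogen, gives an at least 4.6-fold lower number from compound 2 to compound 3 (0.66 log units; beyond the scatter). Compound 3 is thus the only compound shown with a number rather than a limit, while the step between compound 1 and compound 2 still cannot be read. Both readable steps give only a lower bound on size, because one end of each sits at a limit: the limit of > 50000 nM in this assay, at which 2 of the 3 values shown sit.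

The compounds shown do not separate the length of the chain from the terminal dimethylamino group, since an unsubstituted pentyl chain and a 2-(dimethylamino)ethyl chain are not among them. Also open, on these data alone, is whether a 4-methylpiperazin-1-yl group on a pentyl chain, or a primary amine or carboxylic acid at the end of that chain, would give a number or stay at the limit.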